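Sulfonyl cinnamamides: chloro for methyl on the sulfonyl ring

This account rests on a few compounds, and the source may have more. Where it says the series, first, only, none or still open, it means among the compounds named here.

Measured compounds:
compound 1 `O=C(/C=C/c1ccc(Br)cc1)NS(=O)(=O)c1ccc(Cl)cc1`, 5.2 ug/mL
compound 2 `COc1ccc(/C=C/C(=O)NS(=O)(=O)c2ccc(Cl)cc2)cc1`, 5.3 ug/mL
compound 3 `Cc1ccc(S(=O)(=O)NC(=O)/C=C/c2ccc(N(C)C)cc2)cc1`, 4.3 ug/mL

All three share one core and were read in a functional assay on B16-F10 cells (Mus musculus) for antiproliferative activity, read by ELISA and MTT assay, with a stated time of 48 h; a lower number here means a stronger inhibitor, a higher number a weaker inhibitor. Compound 3 stands alongside compound 1 and compound 2: its number lies within the scatter of both, so no ranking among the three is supported.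

Among the measured compounds shown here, the only step measured so far within one change is a 1.0-fold higher number from compound 1 to compound 2 (0.01 log units; within the scatter), a swap on the cinnamoyl ring that left the number essentially unchanged.

Compound 4 `CN(C)c1ccc(/C=C/C(=O)NS(=O)(=O)c2ccc(Cl)cc2)cc1` is not yet measured. It differs from compound 3 by chloro in place of methyl on an aromatic carbon, a change on the sulfonyl-bearing ring rather than the cinnamoyl ring. For the measured compounds named here, no single-change step on that ring has been measured. What the data do show is that compound 1 and compound 2 both carry the 4-chlorophenyl that compound 4 acquires, and their numbers in this assay sit within the scatter of compound 3, which carries the 4-methylphenyl.

On that basis no step beyond the scatter is expected, and the estimate for compound 4 is 4.8 ug/mL with a range of 2.5 ug/mL to 9 ug/mL. The step of a 1.1-fold higher number from compound 3 to compound 4 (0.05 log units; within the scatter) is expected to fall within the scatter.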

Compound 4, half-maximal inhibitory concentration: 2.8 ug/mL
Compound 4: middle estimate off by 1.7-fold (0.23 log units), on the high side; low and high end bracket the measured number.
By their numbers in this assay, from the lowest: compounds 4, 3, 1 and 2 (each within the scatter of the next).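

In this assay, among the compounds shown here, the swap from 4-methylphenyl to 4-chlorophenyl gives the first single-change reading at this position, on an aromatic carbon para to a large group, with a 1.5-fold lower number from compound 3 to compound 4 (0.19 log units; within the scatter), so chloro in place of methyl cannot be told from scatter here. With the 4-chlorophenyl held constant, the other end of the molecule now has three groups to compare: dimethylamino in place of methoxy gives a 1.9-fold lower number from compound 2 to compound 4 (0.28 log units; within the scatter) and dimethylamino in place of bromo gives a 1.9-fold lower number from compound 1 to compound 4 (0.27 log units; within the scatter), so these steps, like a 1.0-fold higher number from compound 1 to compound 2 (0.01 log units; within the scatter), support no ranking. Nothing available gives a reason for any of these steps.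

Open, going by these compounds, is whether a carboxylic acid, an amine or a longer chain at the position held by chloro or methyl would produce a step beyond the scatter. For the compounds shown here, also open is whether chloro in place of methyl reads the same when bromo or methoxy replaces dimethylamino, since the only reading of this swap carries dimethylamino.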